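Replacing nitro with hydrogen on an aromatic carbon

The source may report more compounds than this note shows. Statements on the series, on what has been measured and on what is new or still open speak of the compounds shown alone.

Among the compounds with values here, in a functional assay on MV4-11 cells (Homo sapiens) for inhibition, read by resazurin assay, with a stated time of 72 h (a lower number here means a stronger inhibitor of growth, a higher number a weaker inhibitor of growth), compound 1 `O=[N+]([O-])c1cccc(Nc2ncc3c(n2)CCCC3)c1` gives 3500 nM and holds the higher of the two numbers measured so far. Compound 2 `COc1ccc(Nc2ncc3c(n2)CCC3)cc1` reads 840 nM in the same test, a gap beyond the usual scatter, though its structure differs from compound 1 in more than one place. Compound 3 `c1ccc(Nc2ncc3c(n2)CCCC3)cc1` keeps the core of compound 1 and carries hydrogen in place of nitro on an aromatic carbon of a six-membered aromatic ring of carbon only. Within the data shown here, no measured pair shows this change alone, so the expectation rests on little. Among the measured compounds shown here, with compound 2 at 840 nM as the only other reading, a modest move toward a lower number in this assay is expected, possibly no larger than the scatter. The estimated step of a 1.8-fold lower number from compound 1 to compound 3 (0.24 log units; within the scatter) is of that size. For compound 3 the expected value is 2000 nM (range 700 nM to 5500 nM).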

Compound 3, concentration for 50% growth inhibition: 9830 nM
For compound 3 the middle estimate is 4.9-fold (0.69 log units) below the measured one; measured number above the stated range.
By their numbers in this assay, from the lowest: compound 2; then compound 1; then compound 3.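

In this assay, within the data shown here, hydrogen in place of nitro on an aromatic carbon brings a 2.8-fold higher number from compound 1 to compound 3 (0.45 log units; beyond the scatter) and gives the first reading of this change on its own. At this place, meta to a large group on the six-membered aromatic ring, the nitro group is therefore no burden: of this pair, the compound without it is the weaker inhibitor of growth, though the step is modest. Nothing measured here explains why the number rises.

From the compounds shown here alone, whether this advantage is particular to nitro, or whether another group on the same carbon, such as an amine, a carboxylic acid or a methoxy group, would match or exceed it, stays open. The compounds shown also leave open whether nitro would have the same effect elsewhere on the ring.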